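The source may hold more compounds than are shown below. What is called first, only, known or untested is meant among the compounds shown, and "the series" means these compounds.

Values measured in a functional assay on SW 1116 cells (Homo sapiens) for antiproliferative activity, read by MTT assay, with a stated time of 24 h; on this read-out lower numbers stand for stronger inhibition and higher numbers for weaker inhibition:
- compound 1 `Sc1nnc(-c2ccc3c(c2)OCCO3)n1-c1ccccc1`: 38400 nM
- compound 2 `c1ccc(CSc2nnc(-c3ccc4c(c3)OCCO4)n2-c2ccccc2)cc1`: 7930 nM
- compound 3 `O=[N+]([O-])c1ccc(CSc2nnc(-c3ccc4c(c3)OCCO4)n2-c2ccccc2)cc1`: 13800 nM

Benzyl in place of hydrogen on the sulfur gives a 4.8-fold lower number from compound 1 to compound 2 (0.69 log units; beyond the scatter), and 4-nitrobenzyl in the same place gives a 2.8-fold lower number from compound 1 to compound 3 (0.44 log units; beyond the scatter). Compound 3 therefore has a lower number than compound 1, but it cannot be told apart from compound 2. The nitro in place of hydrogen on an aromatic carbon gives only a 1.7-fold higher number from compound 2 to compound 3 (0.24 log units; within the scatter).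

The next compound is compound 4 `Cc1ccc(CSc2nnc(-c3ccc4c(c3)OCCO4)n2-c2ccccc2)cc1`, which has methyl in place of nitro on an aromatic carbon, para to a large group: methyl in place of nitro on an aromatic carbon. The step that bears most directly on this change is the one at that same carbon, a 1.7-fold higher number from compound 2 to compound 3 (0.24 log units; within the scatter), which stayed within the scatter. Going by the values given here, the data hold no methyl example, so only a small shift is expected in this assay, with no clear direction. The estimate amounts to a 1.4-fold lower number from compound 3 to compound 4 (0.14 log units; within the scatter), which is not expected to exceed the scatter. For compound 4 the estimated value is 10000 nM, with an expected range of 5000 nM to 21000 nM.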

Compound 4, half-maximal inhibitory concentration: 16200 nM
Beside the measured number, compound 4's estimate is 1.6-fold (0.21 log units) below it; the range from low to high includes it.
By their numbers in this assay, from the lowest: compounds 2, 3 and 4 (each within the scatter of the next, the first and the last beyond it); then compound 1.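

In this assay, methyl and nitro at this aromatic carbon, para to a large group, cannot be told apart, with a 1.2-fold higher number from compound 3 to compound 4 (0.07 log units; within the scatter), so replacing one of these two different groups with the other leaves the number within the scatter. Unlike nitro, methyl does separate from hydrogen at this carbon, though only modestly, with a 2.0-fold higher number from compound 2 to compound 4 (0.31 log units; beyond the scatter), while the 4-methylbenzyl on the sulfur still keeps a gain over the free sulfur, with a 2.4-fold lower number from compound 1 to compound 4 (0.37 log units; beyond the scatter). No measured property among these data explains these numbers.

Whether any other group at this carbon would move the number further stays open, since an amine, a carboxylic acid and chlorine are not among the compounds shown. As far as these compounds go, a longer chain between the sulfur and the phenyl ring is likewise absent, so the effect of that distance remains unknown.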